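Ethoxymethyl to Acetyl: One Change on Two Cores

The source may report more compounds than this note shows. Statements on the series, on what has been measured and on what is new or still open speak of the compounds shown alone.

Measured so far:
compound 1, `CCCn1c(=O)n(CCOCC)c(=O)c2[nH]cnc21`: 1900 nM
compound 2, `CCCn1c(=O)n(CC(C)=O)c(=O)c2[nH]cnc21`: 11400 nM
compound 3, `CCCn1c(=O)n(C)c(=O)c2c1ncn2CCOCC`: 24300 nM

All three numbers come from an assay on Cerebral cortex for binding affinity to adenosine receptor A1 (Cavia porcellus), read by radioligand binding; a lower number here means a stronger inhibitor, a higher number a weaker inhibitor. Compound 1 and compound 2 are built on the same core, while compound 3 carries a different arrangement of its side chains; the difference between the two cores is not broken down here. The change from compound 1 to compound 2 is acetyl in place of ethoxymethyl on a saturated chain carbon bound to an aromatic nitrogen. In this assay that change gave a 6.0-fold higher number from compound 1 to compound 2 (0.78 log units; beyond the scatter), so the acetyl compound is the weaker binder of the pair. Compound 3 gives the highest number of the three, and its gap to both compound 1 and compound 2 lies beyond the usual scatter.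

Compound 4, `CCCn1c(=O)n(C)c(=O)c2c1ncn2CC(C)=O`, has not been measured. Among the compounds with values here, it differs from compound 3 by acetyl in place of ethoxymethyl on a saturated chain carbon bound to an aromatic nitrogen, which is the same change, in the same place, as the one between compound 1 and compound 2. The expectation for compound 4 therefore rests on a single precedent: compound 3 should move in the same direction because the same change gave a 6.0-fold higher number from compound 1 to compound 2 (0.78 log units; beyond the scatter) on the other core. Within the data shown here, whether the size carries over exactly is unknown, since only one example is available, and the starting number of compound 3 is already high, so a measurement could end as a limit rather than a number.

In this assay compound 4 is estimated at 100000 nM, with a likely range from 30000 nM to 300000 nM. The estimate for compound 4 means an expected step of a 4.1-fold higher number from compound 3 to compound 4 (0.61 log units; beyond the scatter).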

Compound 4, inhibition constant: 95700 nM
Compound 4: the middle estimate sits 1.0-fold (0.02 log units) above what was measured, and the stated range covers the measured number.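

In this assay, putting acetyl in place of ethoxymethyl on the second core gave a 3.9-fold higher number from compound 3 to compound 4 (0.60 log units; beyond the scatter), so the acetyl compound is again the weaker binder of its pair. Within the data shown here, the change therefore points the same way on both cores, and the sizes of the two steps cannot be told apart: the same change on two cores in this assay, a 6.0-fold higher number (0.78 log units; beyond the scatter) from compound 1 to compound 2 and a 3.9-fold higher number (0.60 log units; beyond the scatter) from compound 3 to compound 4, 1.5-fold (0.18 log units) apart, within the scatter of two such steps This rests on only two pairs in one assay, so it shows that the change carried over between these two cores, but not that it would carry over to any further core, and it gives no explanation for the loss of binding.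

The compounds shown leave open whether other groups on a saturated chain carbon bound to an aromatic nitrogen, such as an amine, a carboxylic acid or a longer ether chain, would bind better or worse than ethoxymethyl and acetyl, and whether any such group would behave alike on both cores. Among these compounds, they also leave open how much each difference in side-chain arrangement contributes to the gap between the two cores, as no pair here changes just one of those differences.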